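Amide for sulfonamide on the anilide nitrogen

This account rests on a few compounds, and the source may have more. Where it says the series, first, only, none or still open, it means among the compounds named here.

Measured so far in an assay on isolated protein for inhibition of phosphoenolpyruvate carboxykinase, cytosolic [GTP] (Homo sapiens); a lower number here means a stronger inhibitor, a higher number a weaker inhibitor:
compound 1 `CCCCn1c(=O)n(Cc2ccccc2F)c(=O)c2[nH]c(Cc3ccc(NC(=O)C(F)(F)F)cc3)nc21` gives 2300 nM;
compound 2 `O=c1c2[nH]c(Cc3ccc(NS(=O)(=O)c4cccc5cccnc45)cc3)nc2n(CC2CC2)c(=O)n1Cc1ccccc1F` gives 450 nM;
compound 3 `O=c1c2[nH]c(Cc3ccc(NS(=O)(=O)c4cccnc4)cc3)nc2n(CC2CC2)c(=O)n1Cc1ccccc1F` gives 1950 nM.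

For the measured compounds named here, compound 3 sits second highest of the three numbers in this assay; compound 1 lies within the scatter of it, while compound 2 stands apart by a 4.3-fold higher number from compound 2 to compound 3 (0.64 log units; beyond the scatter), the only step between neighbours.

Compound 4 `CN(C)CC(=O)Nc1ccc(Cc2nc3c([nH]2)c(=O)n(Cc2ccccc2F)c(=O)n3CC2CC2)cc1` differs from compound 3 by ((dimethylamino)methyl)carbonyl in place of (pyridin-3-yl)sulfonyl on a nitrogen on an aromatic ring. Going by the values given here, the one measured step, from compound 2 to compound 3, changes the group on the sulfonyl sulfur and does not bear directly on exchanging the sulfonyl for a carbonyl. Compound 1, which carries a carbonyl on that nitrogen, gives a number within the scatter of compound 3. No step beyond the scatter is therefore expected for compound 4 in this assay, a 1.0-fold higher number from compound 3 to compound 4 (0.01 log units; within the scatter), with an estimate of 2000 nM (range 600 nM to 6500 nM).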

Compound 4, half-maximal inhibitory concentration: 2070 nM
For compound 4 the middle estimate is 1.0-fold (0.01 log units) below the measured one; measured number inside the range.
By their numbers in this assay, from the lowest: compound 2; then compounds 3, 4 and 1 (each within the scatter of the next).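

In this assay the exchange gives a 1.1-fold higher number from compound 3 to compound 4 (0.03 log units; within the scatter) with the rest of the molecule unchanged; compound 1 could not show this, since it also differs in its butyl chain. On this nitrogen on an aromatic ring, ((dimethylamino)methyl)carbonyl thus takes the place of (pyridin-3-yl)sulfonyl, ring included, without a step beyond the scatter. Nothing on hand gives a reason for this result.

Open, on these data alone, is whether a quinolin-8-yl group on a carbonyl would match its effect on the sulfonyl in compound 2. Also open, as far as these compounds go, is whether the dimethylamino group contributes at all, which a plain acetyl group or a carboxylic acid in its place would test.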